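A few compounds are considered here, and "the series" means these few. Any claim that something is new, unique, unknown or untested is made for them only; others in the source may bear on it.

For the measured compounds named here, compound 1 `CC(=O)Nc1ccc(-c2nc3ccccc3[nH]2)cc1` is one of two compounds measured in an ADME assay on MDBK cells (Bos taurus) for cytotoxicity, read by MTT assay, with a stated time of 96 h; a lower number here means that less compound is tolerated, a higher number that more compound is tolerated. In this assay compound 1 gives > 100000 nM, which is a limit of the assay rather than a number. Compound 2 `CC(=O)Nc1ccc(-c2nc3cc(C(F)(F)F)ccc3[nH]2)cc1` carries trifluoromethyl in place of hydrogen on an aromatic carbon, and in this assay compound 2 gives 50000 nM. Going by the values given here, the only measured step is an at least 2.0-fold lower number from compound 1 to compound 2 (0.30 log units; that floor lies within the scatter); its size cannot be pinned down because of the limit of > 100000 nM in this assay, at which 1 of the 2 values shown sits, and its floor lies within the scatter. The change to compound 3 `O=C(CN1CCCCC1)Nc1ccc(-c2nc3ccccc3[nH]2)cc1` sits elsewhere in the molecule: piperidin-1-yl in place of hydrogen on a saturated chain carbon bound to a carbonyl carbon. Among the compounds with values here, no measured step touches that place, so the step from compound 1 to compound 2 offers no direct guide, and nothing beyond the scatter is expected from this exchange in this assay. The step of a number no higher from compound 1 to compound 3 (the limit leaves the size open) is therefore expected to stay within the scatter. Compound 3 is expected to tolerate a similar amount of compound as the others, with an estimate of 100000 nM and a range from 30000 nM to 300000 nM.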

Compound 3, half-maximal cytotoxic concentration: 18000 nM
Estimate against measurement, compound 3: 5.6-fold (0.74 log units) above, outside the stated range (below it).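

The piperidin-1-yl group sits on a saturated chain carbon bound to a carbonyl carbon, a place that the earlier step did not touch, and in this assay this change gives an at least 5.5-fold lower number from compound 1 to compound 3 (0.74 log units; beyond the scatter). This step lies beyond the scatter, whereas the floor of the step to compound 2 does not, so it is the first change shown that clearly lowers the amount of compound tolerated by the cells. The step can only be stated as a floor, and its true size stays open because its starting point is not a number: the limit of > 100000 nM in this assay, at which 1 of the 3 values shown sits.

The compounds shown do not tell whether the drop belongs to the ring as a whole, to its nitrogen or simply to extending methyl to (piperidin-1-yl)methyl, a question that a morpholine, a dimethylamine or a plain longer carbon chain at the same place could help to answer. Also open, going by these compounds, is how piperidin-1-yl would behave when combined with the trifluoromethyl group of compound 2.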